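The source may report more compounds than this note shows. Statements on the series, on what has been measured and on what is new or still open speak of the compounds shown alone.

In an ADME assay on microsomes from liver (Rattus norvegicus) for metabolic stability, read by LC-MS, with a stated time of 15 min, tested at 1 uM (a higher number here means that more of the compound is left, a lower number that less of the compound is left), compound 1 `O=C(CCS(=O)(=O)c1cccc2ncsc12)N1CCN(c2ccc(Cl)cn2)CC1` gives 31% and stands highest of the three measured compounds. Compound 2 `Cc1cc(F)cnc1N1CCN(C(=O)CCCc2cccc3ncsc23)[C@@H](C)C1` gives 5.3% and compound 3 `Cc1cc(F)cnc1N1CCN(C(=O)CCCc2cccc3ncncc23)[C@@H](C)C1` gives 0% in this series. The gap from compound 1 to each of these two lies beyond the scatter. Compound 4 `O=C(CCS(=O)(=O)c1cccc2ncsc12)N1CCN(c2ccncc2F)CC1` differs from compound 1 in one place, on an amine nitrogen in a ring: 3-fluoropyridin-4-yl in place of 5-chloropyridin-2-yl on an amine nitrogen in a ring at that position. Going by the values given here, the only measured single-place step, a number 5.3 percentage points lower from compound 2 to compound 3 (within the scatter) in this assay, lies elsewhere in the structure, so no measured step covers this change. With compound 1 at 31% as the sole anchor, no step beyond the scatter is expected, and the estimated step is a number 2 percentage points higher from compound 1 to compound 4 (within the scatter) for now. Compound 4 is expected at 33% within an estimated range of 12% to 56% in this assay here.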

Compound 4, percent of the compound remaining: 29%
The estimate for compound 4 lay 4 percentage points above the measured number; the range from low to high includes it.
By their numbers in this assay, from the lowest: compounds 3 and 2 (each within the scatter of the next); then compounds 4 and 1 (each within the scatter of the next).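

Placing 3-fluoropyridin-4-yl in place of 5-chloropyridin-2-yl on the amine nitrogen in the ring gives, in this assay, a number 2 percentage points lower from compound 1 to compound 4 (within the scatter). Going by these compounds alone, this is the first measured step at this position, and the two groups cannot be told apart there in this assay, even though the halogen and the ring nitrogen both differ between them. Nothing at hand accounts for this result.

Open, from the compounds shown here alone, is whether a plain phenyl ring or a pyridine bearing an amine at this position would stay within the scatter of compound 1. Also open, going by these compounds, is whether the same exchange reads alike on the core of compound 2.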